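Swapping 4-Chlorophenyl for 2,4,6-Trifluorophenyl on a Pyrrole Carbon

This account rests on a few compounds, and the source may have more. Where it says the series, first, only, none or still open, it means among the compounds named here.

Measured compounds:
compound 1, `COc1cc(C(=O)c2cn(-c3ccccc3N)cc2-c2ccccc2)cc(OC)c1OC`, gives 3800 nM
compound 2, `COc1cc(C(=O)c2cn(-c3ccccc3)cc2-c2ccc(Cl)cc2)cc(OC)c1OC`, gives 290 nM

Both were tested in a functional assay on MCF7 cells (Homo sapiens) for cytotoxicity, read by MTT assay, with a stated time of 96 h; on this read-out higher numbers stand for weaker inhibition and lower numbers for stronger inhibition. Of the two numbers shown, compound 2 stands at the lowest, and its only neighbour is compound 1, whose higher number lies beyond the scatter. No pair of these compounds differs in only one place, so the two values show a gap but not a step that can be assigned to a single change.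

Compound 3, `COc1cc(C(=O)c2cn(-c3ccccc3)cc2-c2c(F)cc(F)cc2F)cc(OC)c1OC`, has not yet been measured in this assay. It differs from compound 2 in one place: 2,4,6-trifluorophenyl in place of 4-chlorophenyl on an aromatic carbon. For the measured compounds named here, because no measured pair shows what such a change does here, and because the shared core of compound 2 carries a single number, 290 nM, the direction of the step is open. The account expects a modest move toward a higher number, a 2.8-fold higher number from compound 2 to compound 3 (0.44 log units; beyond the scatter), with a wide range on either side. For compound 3 the estimated value in this assay is 800 nM, expected to fall between 200 nM and 4000 nM.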

Compound 3, half-maximal inhibitory concentration: 180 nM
Compound 3: middle estimate off by 4.4-fold (0.65 log units), on the high side; the measured number lies below the stated range.
By their numbers in this assay, from the lowest: compounds 3 and 2 (each within the scatter of the next); then compound 1.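

In this assay, for the compounds shown here, the one step now available at this position reads a 1.6-fold lower number from compound 2 to compound 3 (0.21 log units; within the scatter) and so gives the first reading of a single change. On this aromatic carbon of the five-membered ring, 2,4,6-trifluorophenyl with 9 heavy atoms and 4-chlorophenyl with 7 cannot be told apart by their numbers, whereas the earlier pair offered only a gap that could not be assigned to any one change. Nothing shown here accounts for this outcome, and no measured property of either group bears on it.

The compounds shown leave open whether this position accepts a different kind of group as readily, such as an amine, a carboxylic acid or a longer chain in place of these halogen-bearing phenyl rings, since both groups compared here are aromatic carbon rings with no hydrogen-bond donors or acceptors. They also leave open how much of the gap between compound 1 and compound 2 belongs to the amine on the phenyl at the ring nitrogen, and how much to the chlorine on the phenyl at this carbon.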